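The compounds below may be only part of what the source reports. "The series", "measured", "known", "first", "only" and "open" are said of these compounds alone.

Three compounds share one core and differ only at an oxygen on an aromatic ring. Compound 1 `CC(C)=CCC/C(C)=C/CC1Cc2c(O)cc(=O)n(CCCO)c2CC1(C)C` carries a hydrogen there, and in a functional assay on PANC-1 cells (Homo sapiens) for inhibition, read by MTT assay, with a stated time of 24 h, tested at 10 uM (a lower number here means less inhibition, a higher number more inhibition at the concentration tested (going by the name of the read-out)), compound 1 gives 28.7%. Compound 2 `CCOc1cc(=O)n(CCCO)c2c1CC(C/C=C(\C)CCC=C(C)C)C(C)(C)C2` carries an ethyl and gives 67.8%, a large gain: a number 39.1 percentage points higher from compound 1 to compound 2 (beyond the scatter). Compound 3 `CC(C)=CCC/C(C)=C/CC1Cc2c(OCC=C(C)C)cc(=O)n(CCCO)c2CC1(C)C` carries a 3-methylbut-2-en-1-yl and gives 30.3%; thus a number 1.6 percentage points higher from compound 1 to compound 3 (within the scatter), while a number 37.5 percentage points lower from compound 2 to compound 3 (beyond the scatter). Compound 3 stands second of the three, close to compound 1 and well beneath compound 2.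

Compound 4 `CC(C)=CCC/C(C)=C/COc1cc(=O)n(CCCO)c2c1CC(C/C=C(\C)CCC=C(C)C)C(C)(C)C2` lengthens that chain: 3-methylbut-2-en-1-yl in place of hydrogen on a saturated chain carbon bound to a double-bonded chain carbon, the (3-methylbut-2-en-1-yl)oxy group becoming a (3,7-dimethylocta-2,6-dien-1-yl)oxy group. For the measured compounds named here, the one measured step that also lengthened this chain, a number 37.5 percentage points lower from compound 2 to compound 3 (beyond the scatter), was a large loss, whereas compound 1 and compound 3 lie within the scatter of each other. A further lengthening is expected to shift the number little. For compound 4 the estimate is 30%, between 12% and 55%, an expected step of a number 0.3 percentage points lower from compound 3 to compound 4 (within the scatter).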

Compound 4, a percentage reported as inhibition, at one concentration (the size of the read-out at that concentration, not a potency): 15.8%
Compound 4: middle estimate off by 14.2 percentage points, on the high side; the range from low to high includes it.
By their numbers in this assay, from the lowest: compound 4; then compounds 1 and 3 (each within the scatter of the next); then compound 2.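

The longer chain on this oxygen does lower the number further: the (3,7-dimethylocta-2,6-dien-1-yl)oxy group gives a number 14.5 percentage points lower from compound 3 to compound 4 (beyond the scatter) and so ends below the other two groups. It falls short of the free hydrogen too, with a number 12.9 percentage points lower from compound 1 to compound 4 (beyond the scatter) and the ethyl with a number 52 percentage points lower from compound 2 to compound 4 (beyond the scatter) as well, so here adding this chain is worse than adding nothing. Nothing measured here gives a reason for these steps. As far as these compounds go, what a methyl or a propyl on this oxygen would give stays open. So does the effect of a chain ending in an amine or a carboxylic acid.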